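Swapping Acetyl for Hydrogen on Compound 1

The source may hold more compounds than are shown below. What is called first, only, known or untested is meant among the compounds shown, and "the series" means these compounds.

Within the data shown here, in an ADME assay on HEK293 cells (Homo sapiens) for cytotoxicity, read by MTT assay, with a stated time of 72 h (a higher number here means a weaker inhibitor, a lower number a stronger inhibitor), compound 1 `CC(=O)OC1C/C(=N/O)C(c2ccccc2)=C1c1ccccc1` gives 92.3 ug/mL, the higher of the two numbers so far. Compound 2 `COc1ccc(C2=C(c3cc(OC)c(OC)c(OC)c3)C(=O)CC2O)cc1` gives 10 ug/mL, a lower number by more than the scatter. Compound 3 `O/N=C1/CC(O)C(c2ccccc2)=C1c1ccccc1` differs from compound 1 by hydrogen in place of acetyl on an oxygen on a saturated carbon. Among the measured compounds shown here, no measured pair shows this change, so the size of the step remains uncertain. In this assay, the estimated step of a 1.5-fold lower number from compound 1 to compound 3 (0.19 log units; within the scatter) is expected to stay within the scatter. Compound 3 is expected at 60 ug/mL, within a range of 20 ug/mL to 170 ug/mL.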

Compound 3, half-maximal inhibitory concentration: > 100 ug/mL
Compound 3 ended at the assay's limit; the forecaster's own chance of this, stated with the estimate: 15%; middle value at least 1.6-fold (0.22 log units) away from the limit.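

In this assay, among these compounds, going from acetoxy to hydroxy on this saturated carbon gives the first reading of the change at this position (an at least 1.0-fold higher number from compound 1 to compound 3 (0.03 log units; that floor lies within the scatter)). Compound 3 stands at a limit of the assay, not at a number: (the limit of > 100 ug/mL in this assay, at which 1 of the 3 values shown sits). The free hydroxy thus brings no lower number than the acetoxy, but the true size of the step stays unread. Still open, going by these compounds, is how the number responds to other groups on this oxygen, such as a longer acyl chain or a methyl ether, or to an amine in place of the hydroxy.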